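Methylsulfanyl added to the nucleoside of compound 3

This account rests on a few compounds, and the source may have more. Where it says the series, first, only, none or still open, it means among the compounds named here.

The series rests on a small fused bicyclic core, seen unsubstituted in compound 1 `Cc1nsc2[nH]cnc12`. In a functional assay on HFF cells (Homo sapiens) for inhibition (on this read-out lower numbers stand for stronger inhibition and higher numbers for weaker inhibition), compound 1 gives 32000 nM. Compound 2 `Cc1nsc2[nH]c(SCc3ccccc3)nc12` carries a benzylsulfanyl group on the core, and in this assay compound 2 gives 10000 nM. Compound 3 `Cc1nsc2c1ncn2[C@H]1C[C@H](O)[C@@H](CO)O1` keeps the core of compound 1 but attaches a deoxyribose-type sugar to a ring nitrogen. For compound 3 this assay reports only a limit, > 100000 nM, so compound 3 stands at the weak end of the numbers shown, with no number of its own; it is the one compound at the limit of > 100000 nM in this assay, at which 1 of the 3 values shown sits.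

Compound 4 `CSc1nc2c(C)nsc2n1[C@H]1C[C@H](O)[C@@H](CO)O1` is the next step from compound 3: methylsulfanyl in place of hydrogen on an aromatic carbon. The expectation is that the step from compound 3 to compound 4 is small, a number no higher from compound 3 to compound 4 (the limit leaves the size open), with no clear direction beyond the scatter. Compound 4 is therefore estimated at 100000 nM in this assay, within a range from 30000 nM to 300000 nM, and a further limit rather than a number remains the likelier outcome.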

Compound 4, half-maximal inhibitory concentration: > 100000 nM
Compound 4 was reported as a limit (the forecaster's own chance of this, stated with the estimate: 65%); the middle value sits exactly at the limit.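

Compound 3 and compound 4 are both reported only as limits in this assay, so no step can be read between them: the limit of > 100000 nM in this assay, at which 2 of the 4 values shown sit.

The compounds shown leave open whether methylsulfanyl in place of hydrogen changes inhibition on the nucleoside at all, and in which direction.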